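A few compounds are considered here, and "the series" means these few. Any claim that something is new, unique, unknown or untested is made for them only; others in the source may bear on it.

Measured so far in a functional assay on the whole organism with Rattus norvegicus as the target, at a dose of 100 mg/kg; a lower number here means less inhibition, a higher number more inhibition at the dose given (going by the name of the read-out):

compound 1, `CN(C)/C(=N/CCCCn1nc(-c2ccccc2)ccc1=O)NC#N`: 80.7%
compound 2, `CC/N=C(\S)NCCCCCn1nc(-c2ccccc2)ccc1=O`: 66.4%
compound 3, `CC/N=C(\S)NCCCCn1nc(-c2ccccc2)ccc1=O`: 67.7%

Compound 4, `CN(C)/C(=N/CCCn1nc(-c2ccccc2)ccc1=O)NC#N`, has not been measured in this assay. It differs from compound 3 by a group of 8 heavy atoms (4 carbon, 4 nitrogen; no ring) in place of a group of 7 heavy atoms (4 carbon, 2 nitrogen, 1 sulfur; no ring), on a saturated chain carbon, three bonds along the chain from an aromatic nitrogen.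

The same kind of change is seen once among the measured compounds, from compound 2 to compound 1: a group of 8 heavy atoms (4 carbon, 4 nitrogen; no ring) in place of a group of 7 heavy atoms (4 carbon, 2 nitrogen, 1 sulfur; no ring), on a saturated chain carbon, four bonds along the chain from an aromatic nitrogen. That step gave a number 14.3 percentage points higher from compound 2 to compound 1 (beyond the scatter). The two changes are not the same: in the measured pair the group sits four bonds along the chain from an aromatic nitrogen, whereas in compound 4 it sits three bonds along the chain from an aromatic nitrogen.

The cores of compound 2 and compound 3 differ by a group of 6 heavy atoms (3 carbon, 2 nitrogen, 1 sulfur; no ring) in place of a group of 7 heavy atoms (4 carbon, 2 nitrogen, 1 sulfur; no ring), on a saturated chain carbon, four bonds along the chain from an aromatic nitrogen; that step gave a number 1.3 percentage points higher from compound 2 to compound 3 (within the scatter), so the shorter chain on its own changes little. Compound 1 and compound 3 differ in both places, and a number 13 percentage points lower from compound 1 to compound 3 (beyond the scatter).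

Within the data shown here, for compound 4 the step from compound 3 is expected to be a number 12.3 percentage points higher from compound 3 to compound 4 (beyond the scatter), of about the size of the single earlier step of a number 14.3 percentage points higher from compound 2 to compound 1 (beyond the scatter), because the shorter chain gave a number 1.3 percentage points higher from compound 2 to compound 3 (within the scatter) and so appears not to shift the number on its own. This rests on one measured pair only, and the changed place adds uncertainty. Compound 4 is therefore estimated at 80%, with a range from 68% to 90%.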

Compound 4, a percentage reported as inhibition, in the whole organism at one dose (the size of the read-out at that dose, not a potency): 72.2%
The estimate for compound 4 lay 7.8 percentage points above the measured number; the range from low to high includes it.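

In this assay, the group of 8 heavy atoms (4 carbon, 4 nitrogen; no ring) in place of the group of 7 heavy atoms (4 carbon, 2 nitrogen, 1 sulfur; no ring), now three bonds along the chain from an aromatic nitrogen, gives a number 4.5 percentage points higher from compound 3 to compound 4 (within the scatter). Set beside the earlier step, this result does not separate the two cores: the same change on two cores in this assay, a number 14.3 percentage points higher (beyond the scatter) from compound 2 to compound 1 and a number 4.5 percentage points higher (within the scatter) from compound 3 to compound 4, 9.8 percentage points apart, within the scatter of two such steps

The change may therefore carry over from one core to the other, but with a single pair on each core this does not show that it keeps its size, nor that the place along the chain has no bearing on it; the remaining step, a number 5.8 percentage points higher from compound 2 to compound 4 (within the scatter), alters the chain and the end group together and separates neither.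

The compounds shown leave open whether the step would hold on a longer chain, or on a shorter chain than that of compound 4. They also leave open how an amine or a carboxylic acid at the chain end would compare with the groups seen here, and whether the order of the compounds would hold at other doses.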